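Permeability of a quinoline-urea series: from tert-butyl to (trifluoromethyl)sulfanyl

The source may hold more compounds than are shown below. What is called first, only, known or untested is meant among the compounds shown, and "the series" means these compounds.

Three ureas built on one shared core have been measured in an ADME assay for permeability, using PAMPA, at pH 7.4; a higher number here means that the compound crosses the layer faster, a lower number that the compound crosses the layer more slowly. Compound 1 `Cc1cc(NC(=O)Nc2ccc(C(C)(C)C)cc2)c2ccccc2n1` gives 142 10^-6 cm/s in this assay, the lowest of the three numbers. Compound 2 `COc1ccc(NC(=O)Nc2cc(C)nc3ccccc23)cc1OC` gives 552 10^-6 cm/s in this assay, and compound 3 `CSc1ccccc1NC(=O)Nc1cc(C)nc2ccccc12` gives 1260 10^-6 cm/s in this assay. The gaps from compound 1 to compound 2 and from compound 1 to compound 3 both lie beyond the usual scatter of the method, so compound 1 stands clearly below its two companions. For the measured compounds named here, no pair among the three differs in a single place, so no step between measured compounds can be read off.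

Compound 4 `Cc1cc(NC(=O)Nc2ccc(SC(F)(F)F)cc2)c2ccccc2n1` has not yet been measured in this assay. It differs from compound 1 in one place: (trifluoromethyl)sulfanyl in place of tert-butyl on an aromatic carbon, with the new group sitting on an aromatic carbon of a six-membered aromatic ring of carbon only, para to a large group.

Going by the values given here, with no matching step among the measured compounds, the expectation for compound 4 rests on the position of compound 1 alone. A modest upward step is expected, a 1.8-fold higher number from compound 1 to compound 4 (0.25 log units; within the scatter), which may not exceed the scatter. Compound 4 is therefore estimated at 250 10^-6 cm/s in this assay, within a range from 100 10^-6 cm/s to 600 10^-6 cm/s.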

Compound 4, apparent permeability: 206 10^-6 cm/s
For compound 4 the middle estimate is 1.2-fold (0.08 log units) above the measured one; low and high end bracket the measured number.
By their numbers in this assay, from the lowest: compounds 1 and 4 (each within the scatter of the next); then compound 2; then compound 3.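

In this assay, the series now has its first step that can be read: (trifluoromethyl)sulfanyl in place of tert-butyl on an aromatic carbon, para to a large group, gives a 1.5-fold higher number from compound 1 to compound 4 (0.16 log units; within the scatter). At this position, then, an all-carbon group can give way to one holding sulfur and fluorine, with a hydrogen-bond acceptor where there was none, and the method does not separate compound 1 from compound 4. Nothing at hand bears on why these two groups read alike.

As far as these compounds go, whether a group of another kind at this position, such as an amine or a carboxylic acid, would carry the number beyond the scatter remains open, as does whether the same exchange would read alike at another place on the ring. For the compounds shown here, compound 2 and compound 3 differ from compound 4 in more than one place, so no steps to them can be read, and what sets those two compounds apart from compound 4 stays unresolved.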